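This account rests on a few compounds, and the source may have more. Where it says the series, first, only, none or still open, it means among the compounds named here.

Compound 1 `C=CCCCCCCS(=O)(=O)/C=C/c1ccc(O)c(O)c1`: in a functional assay, read by fluorescence and spectrophotometry, with a stated time of 1 h (on this read-out lower numbers stand for an effect already at smaller amounts and higher numbers for an effect only at larger amounts of compound), compound 1 gives 6400 nM.
Compound 2 `CCCCCCCCCCCS(=O)(=O)/C=C/c1ccc(O)c(O)c1`: in this assay compound 2 gives 11400 nM.
Compound 3 `C=CCCCCCCCS(=O)(=O)/C=C/c1ccc(O)c(O)c1`: in this assay compound 3 gives 6900 nM.

Of the three numbers, compound 3 holds the second highest; a 1.1-fold higher number from compound 1 to compound 3 (0.03 log units; within the scatter), and a 1.7-fold lower number from compound 2 to compound 3 (0.22 log units; within the scatter). Compound 4 `CCCCCCCCCS(=O)(=O)/C=C/c1ccc(O)c(O)c1` differs from compound 3 by ethyl in place of vinyl on a saturated chain carbon, seven bonds along the chain from a sulfonyl sulfur. For the measured compounds named here, three measured steps bear on this change, each within the scatter: a 1.8-fold higher number from compound 1 to compound 2 (0.25 log units; within the scatter), a 1.1-fold higher number from compound 1 to compound 3 (0.03 log units; within the scatter), and a 1.7-fold lower number from compound 2 to compound 3 (0.22 log units; within the scatter). Pentyl in place of vinyl gave only a small drift to a higher number, so ethyl in place of vinyl is expected to give no step beyond the scatter in this assay, at most a slight rise. Compound 4 is therefore estimated at 7500 nM, within 4000 nM to 14000 nM, meaning an expected step of a 1.1-fold higher number from compound 3 to compound 4 (0.04 log units; within the scatter).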

Compound 4, half-maximal effective concentration: 7700 nM
Compound 4: the middle estimate sits 1.0-fold (0.01 log units) below what was measured, and the stated range covers the measured number.
By their numbers in this assay, from the lowest: compounds 1, 3, 4 and 2 (each within the scatter of the next).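

Ethyl in place of vinyl on a saturated chain carbon, seven bonds along the chain from a sulfonyl sulfur, gives a 1.1-fold higher number from compound 3 to compound 4 (0.05 log units; within the scatter) in this assay and so removes the double bond outside aromatic rings without a step beyond the scatter. Propyl in place of vinyl, with a 1.2-fold higher number from compound 1 to compound 4 (0.08 log units; within the scatter) here, and hydrogen in place of ethyl, with a 1.5-fold lower number from compound 2 to compound 4 (0.17 log units; within the scatter) here, also stay within the scatter. No evidence at hand explains this result. From the compounds shown here alone, whether an amine or a carboxylic acid at this place would give a step beyond the scatter remains open.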